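Anilide ring substituent and writhing inhibition

A few compounds are considered here, and "the series" means these few. Any claim that something is new, unique, unknown or untested is made for them only; others in the source may bear on it.

Measured compounds:
compound 1 `COc1cc2c(cc1OC)C(CC(=O)Nc1cccc(Cl)c1)CC2` — 51.5%
compound 2 `COc1cc2c(cc1OC)C(CC(=O)Nc1ccc(Cl)cc1)CC2` — 73.6%
compound 3 `COc1ccccc1NC(=O)CC1CCc2cc(OC)c(OC)cc21` — 24.5%

In a functional assay on the whole organism (strain Swiss Albino) for inhibition, with Mus musculus as the target, in the writhing test, with a stated time of 1 h, at a dose of 100 mg/kg by the oral route (on this read-out lower numbers stand for less inhibition and higher numbers for more inhibition at the one dose given (going by the name of the read-out)), compound 2 stands highest of the three numbers; the steps of a number 22.1 percentage points higher from compound 1 to compound 2 (beyond the scatter) and a number 49.1 percentage points lower from compound 2 to compound 3 (beyond the scatter) both lie beyond the scatter, as does a number 27 percentage points lower from compound 1 to compound 3 (beyond the scatter). Compound 4 `COc1cc2c(cc1OC)C(CC(=O)Nc1ccc([N+](=O)[O-])cc1)CC2` is compound 2 with nitro in place of chloro on an aromatic carbon. Within the data shown here, every measured step swaps one substituted anilide ring for another, and none keeps the 4-position and exchanges only the group there, so no measured step bears directly on this change. The expected step of a number 8.6 percentage points lower from compound 2 to compound 4 (within the scatter) is therefore small, inside the scatter, but the range is set wide. For compound 4 the estimate in this assay is 65%, expected between 40% and 85%.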

Compound 4, a percentage reported as inhibition, in the whole organism at one dose (the size of the read-out at that dose, not a potency): 55.8%
Compound 4: the middle estimate sits 9.2 percentage points above what was measured, within the range that was stated.
By their numbers in this assay, from the lowest: compound 3; then compounds 1 and 4 (each within the scatter of the next); then compound 2.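

In this assay, among these compounds, a number 17.8 percentage points lower from compound 2 to compound 4 (beyond the scatter) is the first step that keeps the place on the aromatic carbon para to a large group and exchanges only the group there. The read-out therefore depends on which group occupies this place, not only on where a substituent sits on the anilide ring. No measurement at hand gives a reason for this step.

With only chloro and nitro at this place, the compounds shown leave open how an amine, a methyl or a carboxylic acid there would read. From the compounds shown here alone, whether any such group would exceed chloro also stays open.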